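This account rests on a few compounds, and the source may have more. Where it says the series, first, only, none or still open, it means among the compounds named here.

Compound 1 `CCn1nc(-c2cccnc2)c2ccccc2c1=O`: 1320 nM
Compound 2 `O=c1c2ccccc2c(-c2cccnc2)nn1Cc1cccc(Cl)c1`: 4170 nM
Compound 3 `O=C(O)CCCn1nc(-c2cccnc2)c2ccccc2c1=O`: > 100000 nM

In a functional assay (trachea) with Cavia porcellus as the target (a higher number here means a weaker inhibitor, a lower number a stronger inhibitor), compound 1 gives 1320 nM, the lowest number in this small set. The entry for compound 3, > 100000 nM, is a limit of the assay and not a number.

Compound 4 `CCn1nc(-n2ccnc2)c2ccccc2c1=O` keeps the ethyl group of compound 1 but carries 1H-imidazol-1-yl in place of pyridin-3-yl on an aromatic carbon. Among the measured compounds shown here, no measured step touches this place, since all three measured compounds carry pyridin-3-yl. The available steps change only the chain on the aromatic nitrogen, so they are indirect guides: a 3.2-fold higher number from compound 1 to compound 2 (0.50 log units; beyond the scatter) is modest, and an at least 75-fold higher number from compound 1 to compound 3 (1.87 log units; beyond the scatter) is large. The carboxylic acid step is a very different kind of change, so the modest step is the closer guide to size. A similar modest step towards a higher number is therefore expected, though with wide uncertainty.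

The expected change is a 2.3-fold higher number from compound 1 to compound 4 (0.36 log units; beyond the scatter). For compound 4 the estimated value in this assay is 3000 nM, with an expected range of 500 nM to 20000 nM.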

Compound 4, half-maximal inhibitory concentration: 5370 nM
Compound 4: the middle estimate sits 1.8-fold (0.25 log units) below what was measured; the measured number falls inside the stated range.
By their numbers in this assay, from the lowest: compound 1; then compounds 2 and 4 (each within the scatter of the next). At a limit, above all of these: compound 3.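

Among the compounds shown here, compound 4 is the first compound here that changes the aromatic ring on the core rather than the chain on the aromatic nitrogen, and in this assay replacing pyridin-3-yl with 1H-imidazol-1-yl gives a 4.1-fold higher number from compound 1 to compound 4 (0.61 log units; beyond the scatter). This shows that the number responds to a change at this position as well, and that pyridin-3-yl gives the lower number of this pair. Even so, the five-membered ring still gives a measured number and not a limit, and nothing at hand explains the difference between the two rings.

The compounds shown leave open how a plain phenyl ring or an amine would behave at this position. They also leave open whether 1H-imidazol-1-yl would produce a step of similar size on compound 2, which carries a different chain.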